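The source may hold more compounds than are shown below. What is called first, only, known or untested is meant among the compounds shown, and "the series" means these compounds.

The common core of the series is seen in compound 1 `Nc1cc(N)c2nc(-c3ccccc3)c(Oc3ccc(Cl)c(Cl)c3)nc2c1`. In a functional assay on 786-0 cells (Homo sapiens) for inhibition, read by sulforhodamine B assay, with a stated time of 48 h (a lower number here means that less compound is tolerated, a higher number that more compound is tolerated), compound 1 gives only a limit, < 100000 nM. Among the compounds with values here, compound 2 `Nc1cc(N)c2nc(-c3ccccc3)c(NCc3ccc(Cl)c(Cl)c3)nc2c1` is the one member with a read number: in this assay compound 2 gives 70800 nM. Compound 3 `Nc1cc(N)c2nc(-c3ccccc3)c(NCc3ccc(F)cc3)nc2c1` in this assay again gives only a limit, < 100000 nM. On the numbers shown, compound 3 thus stands at the edge of what the assay reports, and the limit of < 100000 nM in this assay, at which 2 of the 3 values shown sit, is where two of the three values rest. The step that the two limits leave unreadable from compound 1 to compound 3 and the step that the limit leaves unreadable from compound 2 to compound 3 are both left without a readable size, so neither tells whether compound 3 is more or less tolerated than its neighbours.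

Compound 4 `COc1ccc(Sc2nc3cc(N)cc(N)c3nc2-c2ccccc2)cc1` differs from compound 3 by (4-methoxyphenyl)sulfanyl in place of (4-fluorobenzyl)amino on an aromatic carbon. Within the data shown here, no measured step covers this exchange; what bears on it is only that the whole series sits in one weak band, with compound 2 at 70800 nM. Compound 1 and compound 3 each give only a limit. No step beyond the scatter is therefore expected in this assay, and the expected step that the limit leaves unreadable from compound 3 to compound 4 is small. Compound 4 is estimated at 80000 nM, within a range from 20000 nM to 300000 nM, with a real chance that the assay again reports only a limit.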

Compound 4, concentration lethal to 50% of the cells: 70800 nM
Beside the measured number, compound 4's estimate is 1.1-fold (0.05 log units) above it, and the stated range covers the measured number.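

The exchanges that lead from compound 1 and from compound 3 to compound 4 give no new step of readable size in this assay, since compound 1 and compound 3 each give only a limit: the limit of < 100000 nM in this assay, at which 2 of the 4 values shown sit.

The compounds shown leave open whether any exchange on this aromatic carbon changes the tolerated concentration beyond the scatter.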